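Replacing chloro with a pyridinyl ether on an acylguanidine

The source may hold more compounds than are shown below. What is called first, only, known or untested is meant among the compounds shown, and "the series" means these compounds.

The two measured compounds share an acylguanidine attached to a benzene ring that also carries a methylsulfonyl group and a chloro group. Compound 1 `CCc1cc(Cl)c(S(C)(=O)=O)cc1C(=O)N=C(N)N` carries an ethyl group on that ring, and in a functional assay for inhibition of sodium/hydrogen exchanger (Oryctolagus cuniculus) (on this read-out lower numbers stand for stronger inhibition and higher numbers for weaker inhibition), compound 1 gives 63 nM. Compound 2 `Cc1c(C(=O)N=C(N)N)ccc(Cl)c1S(C)(=O)=O` carries a methyl group instead, arranged differently around the ring, and in this assay compound 2 gives 1300 nM. Compound 2 thus stands at the weaker end of the two numbers, and its gap to compound 1 lies beyond the usual scatter of the measurement.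

Compound 3 `Cc1c(C(=O)N=C(N)N)ccc(Oc2cccnc2)c1S(C)(=O)=O` is compound 2 with one change: (pyridin-3-yl)oxy in place of chloro on an aromatic carbon. Among the compounds with values here, no pair of measured compounds shows what this kind of swap does, so the expectation rests on compound 2 alone. The step from compound 2 to compound 3 is expected to be a 1.6-fold lower number from compound 2 to compound 3 (0.21 log units; within the scatter), which does not clearly go beyond the scatter in either direction. For compound 3 in this assay the estimated value is 800 nM, with a range from 150 nM to 4000 nM.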

Compound 3, half-maximal inhibitory concentration: 2200 nM
Compound 3: middle estimate off by 2.8-fold (0.44 log units), on the low side; measured number inside the range.
By their numbers in this assay, from the lowest: compound 1; then compounds 2 and 3 (each within the scatter of the next).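

In this assay, putting (pyridin-3-yl)oxy in place of chloro on this aromatic carbon, which is ortho to a methylsulfonyl group and para to a group of 6 heavy atoms, gives a 1.7-fold higher number from compound 2 to compound 3 (0.23 log units; within the scatter) and so leaves compound 2 and compound 3 indistinguishable on this read-out. Within the data shown here, this is the first sign of how this position responds to change: a single chlorine atom can give way to a group of 7 heavy atoms carrying its own six-membered aromatic ring with no clear shift in the number. The two hydrogen-bond acceptors that enter with the new group likewise bring no clear shift here, and nothing measured bears on why the two compounds read alike.

The compounds shown leave open whether the ring nitrogen or the ether oxygen of the new group matters at all, which a plain phenoxy group, a directly attached pyridine or an amine such as piperidine on the same carbon could test. They also leave open whether this swap would read the same on the core of compound 1, with its ethyl group and different arrangement around the ring.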